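Bromo to Phenyl on the Outer Ring

A few compounds are considered here, and "the series" means these few. Any claim that something is new, unique, unknown or untested is made for them only; others in the source may bear on it.

Compound 1 `CC(C)(C)c1ccc(CNCCCNS(=O)(=O)c2cc(C(F)(F)F)cc(C(F)(F)F)c2)cc1`, compound 2 `O=S(=O)(NCCCNCc1ccccc1)c1cc(C(F)(F)F)cc(C(F)(F)F)c1` and compound 3 `O=S(=O)(NCCCNCc1ccc(Br)cc1)c1cc(C(F)(F)F)cc(C(F)(F)F)c1` share one core and differ only in the group on the outer aromatic ring. In a functional assay on BXPC-3 cells (Homo sapiens) for inhibition, read by MTT assay, with a stated time of 72 h (on this read-out higher numbers stand for weaker inhibition of growth and lower numbers for stronger inhibition of growth), compound 1 gives 1400 nM, compound 2 gives 13000 nM and compound 3 gives 1500 nM, so compound 3 stands near compound 1 and well apart from compound 2. Compound 4 `O=S(=O)(NCCCNCc1ccc(-c2ccccc2)cc1)c1cc(C(F)(F)F)cc(C(F)(F)F)c1` carries phenyl in place of bromo on an aromatic carbon. Among the measured compounds shown here, two measured steps bear on this change: an 8.7-fold lower number from compound 2 to compound 3 (0.94 log units; beyond the scatter) and a 1.1-fold higher number from compound 1 to compound 3 (0.03 log units; within the scatter), so bromo and tert-butyl at this position each give a lower number than hydrogen, while hardly differing from each other. Compound 4 is therefore expected near 1000 nM, within 300 nM to 4000 nM, an estimated 1.5-fold lower number from compound 3 to compound 4 (0.18 log units; within the scatter).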

Compound 4, concentration for 50% growth inhibition: 1700 nM
Compound 4: middle estimate off by 1.7-fold (0.23 log units), on the low side, and the stated range covers the measured number.
By their numbers in this assay, from the lowest: compounds 1, 3 and 4 (each within the scatter of the next); then compound 2.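

In this assay, a phenyl ring of 6 heavy atoms in place of a single bromo atom leaves the two compounds level (a 1.1-fold higher number from compound 3 to compound 4 (0.05 log units; within the scatter)), and phenyl also stands level with tert-butyl (a 1.2-fold higher number from compound 1 to compound 4 (0.08 log units; within the scatter)). Phenyl still keeps the clear separation from hydrogen (a 7.6-fold lower number from compound 2 to compound 4 (0.88 log units; beyond the scatter)), so the three groups tried here on this aromatic carbon read alike, and only hydrogen stands apart. Nothing measured here gives a reason for this.
As far as these compounds go, whether an amine or a carboxylic acid at this place would stay level with these three remains open. So does the effect of a longer chain there.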